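Benzyl ester in place of acetyl on a penam core

The source may report more compounds than this note shows. Statements on the series, on what has been measured and on what is new or still open speak of the compounds shown alone.

Two compounds share a penicillin-derived core carrying a benzhydryl ester and an exocyclic double bond bearing a carbonyl group. Compound 1 `CC1(C)S[C@@H]2/C(=C\C(=O)c3ccc([N+](=O)[O-])cc3)C(=O)N2[C@H]1C(=O)OC(c1ccccc1)c1ccccc1` holds a 4-nitrophenyl ketone at that position, while compound 2 `CC(=O)/C=C1/C(=O)N2[C@@H]1SC(C)(C)[C@@H]2C(=O)OC(c1ccccc1)c1ccccc1` holds a methyl ketone. In a functional assay on OE19 cells (Homo sapiens) for cytotoxicity, read by MTT assay, with a stated time of 48 h (on this read-out lower numbers stand for stronger inhibition and higher numbers for weaker inhibition), compound 1 gives 44100 nM, and in this assay compound 2 gives 51900 nM. The step of a 1.2-fold higher number from compound 1 to compound 2 (0.07 log units; within the scatter) shows that replacing the aryl ketone by the methyl ketone leaves the number essentially where it was, and compound 2 and compound 1 therefore stand within the scatter of one another.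

Compound 3 `CC1(C)S[C@@H]2/C(=C\C(=O)OCc3ccccc3)C(=O)N2[C@H]1C(=O)OC(c1ccccc1)c1ccccc1` carries the change (benzyloxy in place of methyl on a carbonyl carbon), so that the acetyl group becomes a benzyloxycarbonyl group. For the measured compounds named here, the only measured step that bears on this site is the one from compound 1 to compound 2, which exchanged one carbonyl substituent for another without any movement beyond the scatter. On that basis no step beyond the scatter is expected for compound 3, with a 1.1-fold lower number from compound 2 to compound 3 (0.05 log units; within the scatter) taken as the expected change. Compound 3 is estimated at 46000 nM, with a range from 15000 nM to 140000 nM.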

Compound 3, half-maximal inhibitory concentration: 8200 nM
Beside the measured number, compound 3's estimate is 5.6-fold (0.75 log units) above it, outside the stated range (below it).
By their numbers in this assay, from the lowest: compound 3; then compounds 1 and 2 (each within the scatter of the next).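

In this assay, the substituent on this carbonyl carbon proves able to move the number after all: benzyloxy gives a 6.3-fold lower number from compound 2 to compound 3 (0.80 log units; beyond the scatter) and a 5.4-fold lower number from compound 1 to compound 3 (0.73 log units; beyond the scatter), whereas the two ketones had stayed together with a 1.2-fold higher number from compound 1 to compound 2 (0.07 log units; within the scatter). An aromatic ring in the substituent does not by itself go with the lower number, since compound 1 also carries a six-membered aromatic ring there and still stands within the scatter of compound 2, so among these three compounds only the change to benzyloxycarbonyl separates one from the others. Nothing available explains why this group lowers the number.

The compounds shown leave open whether the lower number follows the oxygen link or the benzyl part of the group, a question that a methoxy group or a benzylamino group on the same carbonyl carbon would help to separate. They also leave open whether the step holds apart from the benzhydryl ester common to all three, for instance with a free carboxylic acid in its place.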